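This account rests on a few compounds, and the source may have more. Where it says the series, first, only, none or still open, it means among the compounds named here.

Among the measured compounds shown here, in a functional assay on A549 cells (Homo sapiens) for inhibition, read by sulforhodamine B assay, with a stated time of 48 h (a higher number here means a weaker inhibitor of growth, a lower number a stronger inhibitor of growth), compound 1 `CN1CCN(CCCOc2cccc3nc(Nc4ccc(Cl)c(C(F)(F)F)c4)ccc23)CC1` gives 1720 nM, the lowest number of the three measured so far. Compound 3 `CN1CCN(CCCOc2cccc3nc(Nc4ccc(F)c(F)c4)ccc23)CC1` gives 3500 nM, and compound 2 `CC(C)c1ccc(Nc2ccc3c(OCCCN4CCN(C)CC4)cccc3n2)cc1` gives 15600 nM. Compound 4 `CN1CCN(CCCOc2cccc3nc(Nc4cc(Cl)cc(Cl)c4)ccc23)CC1` keeps the core of compound 1 and differs in one place, on a nitrogen on an aromatic ring: 3,5-dichlorophenyl in place of 4-chloro-3-(trifluoromethyl)phenyl on a nitrogen on an aromatic ring. There, 3,5-dichlorophenyl replaces 4-chloro-3-(trifluoromethyl)phenyl. The nearest guide is the change to 3,4-difluorophenyl, also a halogen-bearing phenyl, which gave a 2.0-fold higher number from compound 1 to compound 3 (0.31 log units; beyond the scatter). The change to 4-isopropylphenyl, which carries no halogen, gave a 9.1-fold higher number from compound 1 to compound 2 (0.96 log units; beyond the scatter) and is a looser guide. A modest rise is therefore expected, and the estimated step is a 1.7-fold higher number from compound 1 to compound 4 (0.24 log units; within the scatter). Compound 4 is expected at 3000 nM, within an estimated range of 1300 nM to 7000 nM.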

Compound 4, concentration for 50% growth inhibition: 1980 nM
Beside the measured number, compound 4's estimate is 1.5-fold (0.18 log units) above it; the measured number falls inside the stated range.
By their numbers in this assay, from the lowest: compounds 1, 4 and 3 (each within the scatter of the next, the first and the last beyond it); then compound 2.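

With 3,5-dichlorophenyl in place of 4-chloro-3-(trifluoromethyl)phenyl on the nitrogen, the reading stays within the scatter (a 1.2-fold higher number from compound 1 to compound 4 (0.06 log units; within the scatter)), so trifluoromethyl is not required at this position to keep the number of compound 1. The change from 3,4-difluorophenyl also stays within the scatter (a 1.8-fold lower number from compound 3 to compound 4 (0.25 log units; within the scatter)), whereas the change from 4-isopropylphenyl goes beyond it (a 7.9-fold lower number from compound 2 to compound 4 (0.90 log units; beyond the scatter)). All three halogen-bearing phenyl compounds thus give lower numbers than compound 2, though compound 1 and compound 3 themselves differ just beyond the scatter.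

As far as these compounds go, whether a phenyl carrying a nitrile or an amine would group with these compounds or with compound 2 remains open. Nothing shown here explains these steps.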